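The source may report more compounds than this note shows. Statements on the series, on what has been measured and on what is new or still open speak of the compounds shown alone.

Measured so far in a functional assay on A549 cells (Homo sapiens) for cytotoxicity, read by MTT assay, with a stated time of 72 h; on this read-out higher numbers stand for weaker inhibition and lower numbers for stronger inhibition:
compound 1 `COc1ccc(/C=C2\CCC/C(=C\c3cccc(Cl)c3)C2=O)cc1OC` gives 11000 nM
compound 2 `COc1ccc(/C=C2\CCC/C(=C\c3cccc(Br)c3)C2=O)cc1OC` gives 12800 nM
compound 3 `COc1ccc(/C=C2\CCC/C(=C\c3cccc(O)c3)C2=O)cc1OC` gives 4300 nM

Compound 3 at 4300 nM holds the lowest number of the three. Both steps to it lie beyond the scatter and are modest: a 2.6-fold lower number from compound 1 to compound 3 (0.41 log units; beyond the scatter) and a 3.0-fold lower number from compound 2 to compound 3 (0.47 log units; beyond the scatter) in the same direction. Chloro and bromo stay unseparated, with a 1.2-fold higher number from compound 1 to compound 2 (0.07 log units; within the scatter) inside the scatter.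

Next comes compound 4 `COc1ccc(/C=C2\CCC/C(=C\c3ccc(O)c(Cl)c3)C2=O)cc1OC` with the change 3-chloro-4-hydroxyphenyl in place of 3-hydroxyphenyl on a double-bonded chain carbon bound to a double-bonded ring carbon in this series: 3-chloro-4-hydroxyphenyl in place of 3-hydroxyphenyl on a double-bonded chain carbon bound to a double-bonded ring carbon.

The two modest steps bear on this only in part. They replace chloro or bromo by hydroxy, whereas compound 4 keeps a hydroxy and also carries a chloro. Going by the values given here, no measured compound has both groups on that ring, and no measured step moves the hydroxy. Compound 3 at 4300 nM serves as the anchor, and compound 1 at 11000 nM marks the upper side of the likely range.

In this assay no step beyond the scatter is expected, and no firm direction can be given, with a 1.0-fold higher number from compound 3 to compound 4 (0.02 log units; within the scatter) as the estimated move. For compound 4 the estimated value is 4500 nM within an expected range of 1800 nM to 11000 nM at this stage.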

Compound 4, half-maximal inhibitory concentration: > 20000 nM
Compound 4 gave a limit, no number; the forecaster's own chance of this, stated with the estimate: 3%; middle value at least 4.4-fold (0.64 log units) from the limit.
By their numbers in this assay, from the lowest: compound 3; then compounds 1 and 2 (each within the scatter of the next). At a limit, above all of these: compound 4.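

In this assay, compound 4 gives a limit and not a number: the limit of > 20000 nM in this assay, at which 1 of the 4 values shown sits.

Moving from 3-hydroxyphenyl to 3-chloro-4-hydroxyphenyl on the double-bonded chain carbon gives an at least 4.6-fold higher number from compound 3 to compound 4 (0.66 log units; beyond the scatter), so a hydroxy on this aryl group does not by itself keep the lower number seen with compound 3. Against the halogen compounds the result is less sharp: an at least 1.5-fold higher number from compound 2 to compound 4 (0.19 log units; that floor lies within the scatter) and an at least 1.8-fold higher number from compound 1 to compound 4 (0.25 log units; that floor lies within the scatter) leave compound 4 unseparated from either, and adding hydroxy to the chloro-bearing ring of compound 1 has no resolved effect in this assay.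

The compounds shown do not separate the contribution of the chloro from that of the changed hydroxy placement, as the step from compound 3 to compound 4 alters both at once, and the limit leaves the true size of that step unknown. Also open, going by these compounds, is how this position responds to an amine or a carboxylic acid in place of the hydroxy, since only hydroxy, chloro and bromo appear on this aryl group so far.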